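Chain Lengthening Between Aromatic Amine and Phenyl

A few compounds are considered here, and "the series" means these few. Any claim that something is new, unique, unknown or untested is made for them only; others in the source may bear on it.

Measured compounds:
Compound 1 `[SeH]c1nc(NCc2ccccc2)c2cccnc2n1` — in a functional assay on HTB-54 cells (Homo sapiens) for cytotoxicity, read by MTT assay, with a stated time of 72 h (on this read-out lower numbers stand for stronger inhibition of growth and higher numbers for weaker inhibition of growth), compound 1 gives > 100000 nM, a limit of the assay.
Compound 2 `CSc1nc(NCCCc2ccccc2)c2ccccc2n1` — in this assay compound 2 gives > 100000 nM, also a limit of the assay.

Compound 2 thus stands at the limit of > 100000 nM in this assay, at which 2 of the 2 values shown sit, so no number is known for it. Compound 3 `CSc1nc(NCCCCc2ccccc2)c2ccccc2n1` differs from it by benzyl in place of phenyl on a saturated chain carbon, three bonds along the chain from a nitrogen on an aromatic ring. Within the data shown here, no step between measured compounds is known here. With both measured values sitting at the limit, the step in this assay is expected to be a step that the limit leaves unreadable from compound 2 to compound 3, nothing beyond the scatter. Compound 3 is therefore estimated at 150000 nM, within 50000 nM to 500000 nM, and most likely again reported only as a limit.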

Compound 3, concentration for total growth inhibition: > 100000 nM
Compound 3: only a limit was reported; the forecaster's own chance of this, stated with the estimate: 85%; the middle value lies beyond the limit too.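

In this assay, among these compounds, compound 2 and compound 3 both stand only at a limit, and no step between them can be read. The compounds shown leave open whether any chain length gives a measurable value at all.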